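The source may hold more compounds than are shown below. What is called first, only, known or untested is meant among the compounds shown, and "the series" means these compounds.

Compound 1 `CNc1nc(-c2cc(OC)c(OC)c(OC)c2)c(-c2ccc(OC)cc2)s1`: 34.3 nM
Compound 2 `CCOc1ccc(-c2sc(NC)nc2-c2cc(OC)c(OC)c(OC)c2)cc1`: 1.7 nM

In a functional assay on Jurkat cells (Homo sapiens) for antiproliferative activity, read by MTT assay, with a stated time of 72 h (on this read-out lower numbers stand for stronger inhibition and higher numbers for weaker inhibition), compound 2, at 1.7 nM, has the lower of the two numbers. Compound 3 `CCOc1ccc(-c2sc(N(C)C)nc2-c2cc(OC)c(OC)c(OC)c2)cc1` differs from compound 2 in one place: methyl in place of hydrogen on a nitrogen on an aromatic ring. This is methyl in place of hydrogen on a nitrogen on an aromatic ring, so methylamino becomes dimethylamino. Among the compounds with values here, no measured step touches this nitrogen. Within the data shown here, the only measured step, a 20-fold lower number from compound 1 to compound 2 (1.30 log units; beyond the scatter), was large, but it lies on a saturated chain carbon bound to an oxygen on an aromatic ring. It shows only that one added methyl elsewhere in the series moved this assay beyond the scatter. Starting from the low value of compound 2, a move toward weaker inhibition seems likelier than a further gain. The expected step is a 15-fold higher number from compound 2 to compound 3 (1.17 log units; beyond the scatter), and this estimate is uncertain. Compound 3 is expected at 25 nM, with an estimated range of 4 nM to 200 nM.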

Compound 3, half-maximal inhibitory concentration: 4150 nM
Beside the measured number, compound 3's estimate is 170-fold (2.22 log units) below it, outside the stated range (above it).
By their numbers in this assay, from the lowest: compound 2; then compound 1; then compound 3.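

In this assay, within the data shown here, the nitrogen on an aromatic ring proves far more sensitive than the earlier compounds could show: a single added methyl, turning methylamino into dimethylamino, gives a 2400-fold higher number from compound 2 to compound 3 (3.39 log units; beyond the scatter). This step runs in the opposite direction to a 20-fold lower number from compound 1 to compound 2 (1.30 log units; beyond the scatter), which lay on a saturated chain carbon bound to an oxygen on an aromatic ring, so one added methyl can strengthen or weaken the read-out depending on where it enters. Nothing measured here gives a reason for the size of this loss.

As far as these compounds go, it remains open whether the loss belongs to the second methyl specifically or to the departure of the hydrogen from this nitrogen. How an unsubstituted amine, an ethylamino group or an acetamide would read at this place in this assay also stays unresolved.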